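This account rests on a few compounds, and the source may have more. Where it says the series, first, only, none or still open, it means among the compounds named here.

Of the compounds shown here, three sharing one core have been measured in an ADME assay on the whole organism (strain Sprague-Dawley) for metabolic stability, with Rattus norvegicus as the target, read by LC-MS; a higher number here means that the compound lasts longer, a lower number that the compound disappears faster. Compound 1 `O=C(COc1nn(-c2ccccc2F)c2ccc(F)cc12)N1CCOCC1` gives 1.6 h, compound 2 `Fc1ccc2c(c1)c(OCCn1ccnc1)nn2-c1ccccc1F` gives 1.1 h, and compound 3 `O=C1NCCN1CCOc1nn(-c2ccccc2F)c2ccc(F)cc12` gives 0.4 h. Compound 3 stands lowest of the three: the steps of a 4.0-fold lower number from compound 1 to compound 3 (0.60 log units; beyond the scatter) and a 2.8-fold lower number from compound 2 to compound 3 (0.44 log units; beyond the scatter) both lie beyond the scatter, while the step of a 1.5-fold lower number from compound 1 to compound 2 (0.16 log units; within the scatter) does not. Compound 4 `O=C1NCCN1CCOc1nn(-c2ccc(F)cc2F)c2ccc(F)cc12` differs from compound 3 in one place: fluoro in place of hydrogen on an aromatic carbon. Cut one bond further out, the change reads 2-fluorophenyl to 2,4-difluorophenyl. Among the compounds with values here, every measured step so far concerns the chain attached through the oxygen of the core, not the aromatic ring that already carries a fluoro group, so no measured step bears directly on this change. With nothing pointing either way, the expectation for compound 4 is a step of a 1.3-fold higher number from compound 3 to compound 4 (0.10 log units; within the scatter) that stays within the scatter. Compound 4 is therefore estimated at 0.5 h, with a range from 0.25 h to 1 h.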

Compound 4, half-life: 0.94 h
Compound 4: the middle estimate sits 1.9-fold (0.27 log units) below what was measured, and the stated range covers the measured number.
By their numbers in this assay, from the lowest: compound 3; then compounds 4, 2 and 1 (each within the scatter of the next).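

The 2-fluorophenyl ring now comes into play: every earlier step lay in the chain attached through the oxygen of the core, whereas here fluoro in place of hydrogen, on the aromatic carbon para to a large group, gives a 2.4-fold higher number from compound 3 to compound 4 (0.37 log units; beyond the scatter) in this assay. This shows that the ring position can also shift the half-life, and that entry of a single heavy atom can carry a step beyond the scatter. Nothing measured here explains why the number moves.

Going by these compounds, this is one pair on one chain, so it remains open whether the same fluoro would raise the number with the (morpholin-4-yl)carbonyl group of compound 1 or the 1H-imidazol-1-yl group of compound 2. Also open, on these data alone, is how chloro, methoxy or a nitrile on this carbon would compare with fluoro.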